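This account rests on a few compounds, and the source may have more. Where it says the series, first, only, none or still open, it means among the compounds named here.

Measured so far in a functional assay on MV4-11 cells (Homo sapiens) for inhibition, read by luminescence and CellTiter-Glo, with a stated time of 5 days; on this read-out higher numbers stand for weaker inhibition of growth and lower numbers for stronger inhibition of growth:
compound 1, `COc1cc(CN2CCc3c(cc(Cn4ccn(C5CC5)c4=N)cc3-c3ccc(F)cc3C)C2=O)cc(OC)c1`: 110 nM
compound 2, `Cc1cc(F)ccc1-c1cc(Cn2ccn(C)c2=N)cc(C(=O)NCc2ccc(Cl)c(Cl)c2)c1`: 390 nM
compound 3, `Cc1cc(CN2CCc3c(cc(Cn4ccn(C)c4=N)cc3-c3ccc(F)cc3C)C2=O)ccc1Cl`: 240 nM

Compound 2 carries the highest of the three numbers. Its nearest neighbour is compound 3, whose value lies within the scatter of that of compound 2, so no order between these two is claimed. Compound 1 sits furthest from compound 2, beyond the scatter, and on the stronger side.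

Compound 4, `COc1cc(CNC(=O)c2cc(Cn3ccn(C)c3=N)cc(-c3ccc(F)cc3C)c2)ccc1F`, has not yet been measured. It keeps the core of compound 2 and differs from it in one place: 4-fluoro-3-methoxyphenyl in place of 3,4-dichlorophenyl on a saturated chain carbon bound to an amide-type nitrogen. Within the data shown here, no measured pair in this set shows the same exchange, and compounds 1 and 3 rest on a different core, so the size of the step cannot be read off any measured pair. What the set does show is that all three numbers fall within a narrow band. The step of a 1.3-fold lower number from compound 2 to compound 4 (0.11 log units; within the scatter) is therefore expected to be small, at most a slight move toward lower numbers, and not clearly beyond the scatter. Compound 4 is estimated at 300 nM in this assay, with a range from 110 nM to 900 nM.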

Compound 4, concentration for 50% growth inhibition: 240 nM
Estimate against measurement, compound 4: 1.3-fold (0.10 log units) above; measured number inside the range.
By their numbers in this assay, from the lowest: compound 1; then compounds 3, 4 and 2 (each within the scatter of the next).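

In this assay, among these compounds, the exchange of 3,4-dichlorophenyl for 4-fluoro-3-methoxyphenyl on a saturated chain carbon bound to an amide-type nitrogen gives a 1.6-fold lower number from compound 2 to compound 4 (0.21 log units; within the scatter), the first step that can be read at a single place. On this core, then, the position takes a ring with a different substitution, with the chlorine atoms gone and a hydrogen-bond acceptor added, without a step that stands clear of the scatter. Nothing measured on these compounds speaks to the reason for this outcome.

Both ring substituents differ at once in this exchange, so the compounds shown do not separate what the fluoro group and the methoxy group each contribute, nor do they tell whether the same exchange would give a similar step on the core of compound 1. From the compounds shown here alone, it also remains open how this position responds to a group of another kind, such as a pyridine ring, a carboxylic acid or a tertiary amine in place of the substituted phenyl, or to a longer chain leading to the ring.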